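This account rests on a few compounds, and the source may have more. Where it says the series, first, only, none or still open, it means among the compounds named here.

Measured compounds:
- compound 1, `CCC(C)(C)Cc1c[nH]c(CCc2ccc(-n3ncnn3)cc2)n1`: 99 nM in a functional assay on HEK293 cells for agonist activity at Bombesin receptor subtype-3 (Mus musculus), read by luminescence and calcium flux, with a stated time of 10 min; a higher number here means that more compound is needed for the effect, a lower number that less compound is needed
- compound 2, `CCC(C)(C)Cc1c[nH]c(CCc2ccc(-n3ccnn3)cc2)n1`: 111 nM in this assay
- compound 3, `CCC(C)(C)Cc1c[nH]c(CCc2ccc(-c3cccc(C#N)n3)cc2)n1`: 115 nM in this assay

Compound 2 gives the second highest of the three numbers, but its steps to the other two are both within the scatter: a 1.1-fold higher number from compound 1 to compound 2 (0.05 log units; within the scatter) and a 1.0-fold higher number from compound 2 to compound 3 (0.02 log units; within the scatter). Compound 4, `CCC(C)(C)Cc1c[nH]c(CCc2ccc(-c3cccnc3C(=O)O)cc2)n1`, is not yet measured. From compound 2 it changes as follows: 2-carboxypyridin-3-yl in place of 1H-1,2,3-triazol-1-yl on an aromatic carbon. For the measured compounds named here, the steps that bear on this each swap one group at that same place: a 1.1-fold higher number from compound 1 to compound 2 (0.05 log units; within the scatter), a 1.0-fold higher number from compound 2 to compound 3 (0.02 log units; within the scatter) and a 1.2-fold higher number from compound 1 to compound 3 (0.07 log units; within the scatter). All three lie within the scatter, so three different groups there gave about the same number. Going by the values given here, none of the measured compounds carries a carboxylic acid, so that comparison rests on less evidence, and a modest rise is expected, a 1.8-fold higher number from compound 2 to compound 4 (0.26 log units; within the scatter). Compound 4 is estimated at 200 nM, in the range 70 nM to 700 nM.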

Compound 4, half-maximal effective concentration: 97 nM
Compound 4: middle estimate off by 2.1-fold (0.31 log units), on the high side; the measured number falls inside the stated range.
By their numbers in this assay, from the lowest: compounds 4, 1, 2 and 3 (each within the scatter of the next).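

For the compounds shown here, the larger 2-carboxypyridin-3-yl, the first group here to carry a carboxylic acid, changes little at this place: a 1.1-fold lower number from compound 2 to compound 4 (0.06 log units; within the scatter), a 1.2-fold lower number from compound 3 to compound 4 (0.07 log units; within the scatter) and a 1.0-fold lower number from compound 1 to compound 4 (0.01 log units; within the scatter). In this assay, four different groups on this aromatic carbon now give about the same number, so neither the added heavy atoms nor the acid separates compound 4 from the others. No measurement shown here gives a reason for this. As far as these compounds go, it remains open whether any group at this place moves the number beyond the scatter. An amine, a longer chain or a bare hydrogen there could still show this.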